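Carbamate ester group variation on the shared core

The source may hold more compounds than are shown below. What is called first, only, known or untested is meant among the compounds shown, and "the series" means these compounds.

Compound 1 `Cc1nc(S(C)(=O)=O)ccc1Oc1ncnc(OC2CCN(C(=O)OC(C)(C)CF)CC2)c1F` gives 19.9 nM in a functional assay on isolated protein for inhibition of Glucose-dependent insulinotropic receptor (Homo sapiens), read by HTRF and cAMP accumulation; a higher number here means that more compound is needed for the effect, a lower number that less compound is needed. Compound 2 `Cc1nc(S(C)(=O)=O)ccc1Oc1ncnc(OC2CCN(C(=O)O[C@@H](C)CF)CC2)c1F` gives 186 nM. Compound 3 `Cc1nc(S(C)(=O)=O)ccc1Oc1ncnc(OC2CCN(C(=O)OC3COC3)CC2)c1F` gives 326 nM.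

Compound 3 stands at the highest of the three numbers; its gap to compound 2 is within the scatter, as a 1.8-fold higher number from compound 2 to compound 3 (0.24 log units; within the scatter) shows, while the step of a 16-fold higher number from compound 1 to compound 3 (1.21 log units; beyond the scatter) is large and beyond the scatter. Compound 4 `Cc1nc(S(C)(=O)=O)ccc1Oc1ncnc(OC2CCN(C(=O)OC3(C(F)(F)F)CCC3)CC2)c1F` differs from compound 3 by 1-(trifluoromethyl)cyclobutyl in place of oxetan-3-yl on an oxygen next to a carbonyl group. The entering group carries fluorine and has no hydrogen-bond acceptor, in that respect closer to the group of compound 1 than to oxetan-3-yl. The steps of a 16-fold higher number from compound 1 to compound 3 (1.21 log units; beyond the scatter) and a 9.3-fold higher number from compound 1 to compound 2 (0.97 log units; beyond the scatter) bear on this change; both were beyond the scatter. A large step back down is therefore expected in this assay, a 13-fold lower number from compound 3 to compound 4 (1.12 log units; beyond the scatter). Compound 4 is estimated at 25 nM, range 8 nM to 80 nM.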

Compound 4, half-maximal effective concentration: 14.3 nM
For compound 4 the middle estimate is 1.7-fold (0.24 log units) above the measured one; the range from low to high includes it.
By their numbers in this assay, from the lowest: compounds 4 and 1 (each within the scatter of the next); then compounds 2 and 3 (each within the scatter of the next).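

In this assay the position on an oxygen next to a carbonyl group accepts 1-(trifluoromethyl)cyclobutyl, with a 23-fold lower number from compound 3 to compound 4 (1.36 log units; beyond the scatter) and a 13-fold lower number from compound 2 to compound 4 (1.11 log units; beyond the scatter) as the two large steps. With a 1.4-fold lower number from compound 1 to compound 4 (0.14 log units; within the scatter) the cyclic group and the open 1-(fluoromethyl)-1-methylethyl group cannot be told apart, so a ring at this position is compatible with the low numbers. No measurement at hand accounts for these steps.

Open, from the compounds shown here alone, is whether the ring or the fluorine carries the effect, which plain cyclobutyl or tert-butyl would separate. A cyclohexyl group would test how much larger the group can become.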